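The source may report more compounds than this note shows. Statements on the series, on what has been measured and on what is new or still open speak of the compounds shown alone.

The compounds measured in a functional assay on HL-60 cells (Homo sapiens) for cytotoxicity, read by luminescence and CellTiter-Glo, with a stated time of 3 days; on this read-out lower numbers stand for stronger inhibition and higher numbers for weaker inhibition:

Compound 1, `O=C(Nc1cc(C(F)(F)F)cc(C(F)(F)F)c1)c1cc(Br)c(F)cc1O`, gives 250 nM.
Compound 3, `O=C(Nc1cc(C(F)(F)F)cc(C(F)(F)F)c1)c1cc(Br)ccc1O`, gives 290 nM.
Compound 2, `N#Cc1ccc(NC(=O)c2ccccc2O)cc1`, gives 4620 nM.

Compound 1 and compound 3 share a core and differ in a single place: fluoro in place of hydrogen on an aromatic carbon. In this assay that change gave a 1.2-fold lower number from compound 3 to compound 1 (0.06 log units; within the scatter), so within this pair the number was left essentially where it was.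

Compound 2 carries a nitrile rather than the two trifluoromethyl groups of compound 3, and the difference between the two cores is not broken down here. Compound 2 stands at the highest of the three measured numbers, and its gaps to compound 3 and to compound 1 are both beyond the scatter.

Compound 4, `N#Cc1ccc(NC(=O)c2ccc(F)cc2O)cc1`, has not yet been measured. It differs from compound 2 in one place: fluoro in place of hydrogen on an aromatic carbon. This is the same kind of change as that from compound 3 to compound 1, not the same change: in compound 1 the new fluoro is ortho to a bromo group, meta to a hydroxy group and para to a large group, whereas in compound 4 there is no bromo group, the fluoro being meta to a hydroxy group and para to a large group. Going by the values given here, the only measured example of this kind of change, a 1.2-fold lower number from compound 3 to compound 1 (0.06 log units; within the scatter), lay within the scatter, so a similarly small step is expected from compound 2 to compound 4, with wide uncertainty: there is one example only, and the cores differ. Compound 4 is therefore expected at 4000 nM. Compound 4 is expected to fall between 1500 nM and 11000 nM. This corresponds to an expected step of a 1.2-fold lower number from compound 2 to compound 4 (0.06 log units; within the scatter).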

Compound 4, half-maximal inhibitory concentration: 1380 nM
Beside the measured number, compound 4's estimate is 2.9-fold (0.46 log units) above it; the measured number lies below the stated range.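

In this assay, fluoro in place of hydrogen on an aromatic carbon gave a 3.3-fold lower number from compound 2 to compound 4 (0.52 log units; beyond the scatter), so on the core of compound 2 this small change moved the number by more than the usual scatter of repeated measurements. Set beside the earlier pair, the change did not carry its size over from one core to the other, and a step read on one core is therefore a poor guide to the step on the other: the same change on two cores in this assay, a 1.2-fold lower number (0.06 log units; within the scatter) from compound 3 to compound 1 and a 3.3-fold lower number (0.52 log units; beyond the scatter) from compound 2 to compound 4, 2.9-fold (0.46 log units) apart, beyond the scatter of two such steps

Going by these compounds alone, this rests on only two pairs, and the two cores differ in more than one place, with a nitrile in compound 2 and compound 4 but two trifluoromethyl groups and a bromo group in compound 1 and compound 3, so it shows neither which of those differences matters nor why the steps differ.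

The compounds shown leave open whether the larger step belongs to the nitrile, to the missing bromo group or to the two together, which a core carrying only one of those differences could help to separate. They also leave open how a different group in the place of the fluoro, such as chloro, a methoxy group or an amine, would behave on either core.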